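Swapping an aryl group on sulfur in a nucleoside series

The source may report more compounds than this note shows. Statements on the series, on what has been measured and on what is new or still open speak of the compounds shown alone.

Measured compounds:
compound 1, `Nc1nc(SCc2ccccn2)c2ncn([C@@H]3O[C@H](CO)[C@@H](O)[C@H]3O)c2n1`, 34700 nM
compound 2, `CSc1ncnc2c1c(Br)cn2[C@@H]1O[C@H](CO)[C@@H](O)[C@H]1O`, 115000 nM
compound 3, `Cc1cc(C)c(SCc2ncnc3c2ncn3[C@@H]2O[C@H](CO)[C@@H](O)[C@H]2O)c(C)c1`, 33100 nM

In an assay on isolated protein for binding affinity to Equilibrative nucleoside transporter 1 (Homo sapiens) (a higher number here means a weaker inhibitor, a lower number a stronger inhibitor), compound 3 and compound 1 give values within the usual scatter of each other, so neither can be set above the other. Compound 2 gives a number beyond the scatter higher than compound 3, making it the weaker inhibitor of the two.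

Compound 4, `O=[N+]([O-])c1cccc(SCc2ncnc3c2ncn3[C@@H]2O[C@H](CO)[C@@H](O)[C@H]2O)c1`, has not yet been measured. It differs from compound 3 in one place: 3-nitrophenyl in place of 2,4,6-trimethylphenyl on a sulfur. No comparable change is among the measured pairs, so the direction is open; a step within or only slightly beyond the scatter seems most likely.

The value for compound 4 is estimated at 30000 nM, between 8000 nM and 120000 nM, which means an expected step of a 1.1-fold lower number from compound 3 to compound 4 (0.04 log units; within the scatter) in this assay.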

Compound 4, half-maximal inhibitory concentration: 4.79 nM
The estimate for compound 4 lay 6300-fold (3.80 log units) above the measured number; measured number outside the range, below it.
By their numbers in this assay, from the lowest: compound 4; then compounds 3 and 1 (each within the scatter of the next); then compound 2.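

In this assay, the group on the sulfur proves decisive, with a step of a 6900-fold lower number from compound 3 to compound 4 (3.84 log units; beyond the scatter) for this single swap. Both groups have the same heavy-atom count, so that count alone does not set the value at this position. No available measurement explains the step. The swap removes three methyl groups and adds a nitro group at once, so their separate contributions cannot be read. An unsubstituted phenyl group would help separate them, while an amine or a nitrile on the ring remains untested among the compounds shown here.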